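The compounds below may be only part of what the source reports. "The series", "measured", "known", "first", "only" and "open" are said of these compounds alone.

Measured compounds:
compound 1, `COC(=O)C1=C(N)Oc2c(OC)cc(Br)cc2C1CC(=O)c1ccc(Br)cc1`: 50.2%
compound 2, `COC(=O)C1=C(N)Oc2ccc(Br)cc2C1CC(=O)c1ccc(Br)cc1`: 72.5%

Of the compounds shown here, two have been measured in a functional assay on MCF7 cells (Homo sapiens) for antiproliferative activity, read by sulforhodamine B assay, with a stated time of 72 h, tested at 10 uM; on this read-out higher numbers stand for a weaker effect at the one concentration tested and lower numbers for a stronger effect. Compound 1 `COC(=O)C1=C(N)Oc2c(OC)cc(Br)cc2C1CC(=O)c1ccc(Br)cc1` gives 50.2%, and compound 2 `COC(=O)C1=C(N)Oc2ccc(Br)cc2C1CC(=O)c1ccc(Br)cc1` gives 72.5%. Among the compounds with values here, the single step between them, a number 22.3 percentage points higher from compound 1 to compound 2 (beyond the scatter), concerns hydrogen in place of methoxy on an aromatic carbon. Compound 2 therefore stands at the highest of the two numbers, which on this read-out means the weaker effect at the one concentration tested.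

Compound 3 `N#CC1=C(N)Oc2ccc(Br)cc2C1CC(=O)c1ccc(Br)cc1` has not yet been measured. It differs from compound 2 in one place: cyano in place of methoxycarbonyl on a double-bonded ring carbon. Methoxycarbonyl leaves and cyano enters; the rest of the shared core is unchanged.

Within the data shown here, no measured step bears on this kind of change: the only step known concerns the aromatic methoxy, not the group on the double-bonded ring carbon, so it gives no guide to direction. The expected step in this assay, a number 2.5 percentage points lower from compound 2 to compound 3 (within the scatter), is therefore set close to none beyond the scatter, with a wide range to cover either direction. Compound 3 is thus estimated at 70%, within a range from 45% to 95%.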

Compound 3, a percentage reported as activity, at one concentration (the size of the read-out at that concentration, not a potency): 47.2%
The estimate for compound 3 lay 22.8 percentage points above the measured number; the range from low to high includes it.
By their numbers in this assay, from the lowest: compounds 3 and 1 (each within the scatter of the next); then compound 2.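

In this assay, the group on the double-bonded ring carbon proves to matter: replacing methoxycarbonyl with cyano gives a number 25.3 percentage points lower from compound 2 to compound 3 (beyond the scatter), and a lower number here stands for a stronger effect at the one concentration tested. Within the data shown here, the earlier step concerned only a methoxy on an aromatic carbon, so this is the first sign that a second, separate place on the shared core can also shift the read-out. The entering cyano has 2 heavy atoms and 1 hydrogen-bond acceptor where methoxycarbonyl has 4 and 2, yet nothing measured here tells which difference between the two groups, if any, lies behind this step.

Still open, from the compounds shown here alone, is how other groups would behave at this ring carbon, such as a carboxylic acid, a primary amide or an ethyl ester, and whether the result belongs to cyano alone or extends to a wider range of groups. Going by these compounds, it is also open whether the two changes seen so far would add up, which only a compound carrying both cyano and the aromatic methoxy could show.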